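Permeability of a Methyl-to-Hydrogen Pair on a Shared Amide Series

A few compounds are considered here, and "the series" means these few. Any claim that something is new, unique, unknown or untested is made for them only; others in the source may bear on it.

Compound 1 `O=C(c1cccc(C(F)(F)c2n[nH]c(=O)c3c2CCCC3)c1)N1CCn2c(nnc2C(F)(F)F)C1` gives 1.3 10^-6 cm/s in an ADME assay on Caco-2 cells (Homo sapiens) for permeability, read by LC-MS, with a stated time of 2 h, at pH 7.4, tested at 10 uM; on this read-out higher numbers stand for higher permeability and lower numbers for lower permeability.
Compound 2 `C[C@@H]1Cn2c(nnc2C(F)(F)F)CN1C(=O)c1cccc(C(F)(F)c2n[nH]c(=O)c3c2CCCC3)c1` gives 1.8 10^-6 cm/s in this assay.
Compound 3 `C[C@@H]1Cn2c(nnc2C(F)(F)F)CN1C(=O)c1cccc(Cc2n[nH]c(=O)c3c2CCCC3)c1` gives 0.3 10^-6 cm/s in this assay.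

Compound 2 and compound 1 differ by hydrogen in place of methyl on a saturated ring carbon, and this change gives a 1.4-fold lower number from compound 2 to compound 1 (0.14 log units; within the scatter). The two numbers therefore cannot be set apart with confidence.

Compound 3 carries the same methyl on the same saturated ring carbon as compound 2, but its core is different; the difference between the two cores is not broken down here. In this assay compound 3 stands at the lowest of the three numbers, and both compound 1 and compound 2 lie beyond the scatter above it.

Compound 4 `O=C(c1cccc(Cc2n[nH]c(=O)c3c2CCCC3)c1)N1CCn2c(nnc2C(F)(F)F)C1` has not yet been measured. It differs from compound 3 by hydrogen in place of methyl on a saturated ring carbon, which is the same kind of change as that between compound 2 and compound 1, made on the core of compound 3. Since the earlier step was a 1.4-fold lower number from compound 2 to compound 1 (0.14 log units; within the scatter), compound 4 is expected to sit close to compound 3, with an expected step of a 1.2-fold lower number from compound 3 to compound 4 (0.08 log units; within the scatter). This expectation rests on the value of compound 3, 0.3 10^-6 cm/s, and on the small size of the earlier step; compound 4 is estimated at 0.25 10^-6 cm/s, most likely between 0.1 10^-6 cm/s and 0.6 10^-6 cm/s.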

Compound 4, apparent permeability: 0.4 10^-6 cm/s
Beside the measured number, compound 4's estimate is 1.6-fold (0.20 log units) below it, within the range that was stated.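

In this assay, hydrogen in place of methyl on a saturated ring carbon, carried onto the second core, gives a 1.3-fold higher number from compound 3 to compound 4 (0.12 log units; within the scatter), so this pair cannot be set apart with confidence any more than the first pair could. Set beside the earlier step, the new step shows no difference between the two cores that can be told from the ordinary spread of such measurements: the same change on two cores in this assay, a 1.4-fold lower number (0.14 log units; within the scatter) from compound 2 to compound 1 and a 1.3-fold higher number (0.12 log units; within the scatter) from compound 3 to compound 4, 1.8-fold (0.27 log units) apart, within the scatter of two such steps. Among these compounds, the two steps thus show that, on these two cores, the change produces no step beyond the scatter, but with only two pairs they cannot reveal a small real effect of either sign, and they do not show that the same would hold on any other core.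

The compounds shown carry only methyl or hydrogen on this saturated ring carbon, so it remains open how an ethyl group, a hydroxyl group or an amine placed there would read in this assay. Also open is how the methyl with the opposite stereochemistry at that carbon would compare, since every methyl compound shown has the same arrangement.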